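A few compounds are considered here, and "the series" means these few. Any claim that something is new, unique, unknown or untested is made for them only; others in the source may bear on it.

Compound 1 `Cc1cn(COC(CO)CO)c(=O)[nH]c1=O`: in a functional assay on Vero cells (Chlorocebus sabaeus) for cytotoxicity (on this read-out higher numbers stand for lower toxicity in this test and lower numbers for higher toxicity in this test), compound 1 gives > 434000 nM, a limit of the assay.
Compound 2 `O=c1[nH]c(=O)n(COC(CO)CO)cc1CO`: in this assay compound 2 gives > 406000 nM, a limit of the assay.
Compound 3 `O=c1cnn(COC(CO)CO)c(=O)[nH]1`: in this assay compound 3 gives > 460000 nM, a limit of the assay.

Going by the values given here, compound 3 stands at a limit, as the limit of > 460000 nM in this assay, at which 1 of the 3 values shown sits, shows; the other two values shown are limits as well, so no compound is placed above another. Among the compounds with values here, the one step between measured compounds, a step that the two limits leave unreadable from compound 1 to compound 2, cannot be read from two limits. Compound 4 `Cc1nn(COC(CO)CO)c(=O)[nH]c1=O` differs from compound 3 by methyl in place of hydrogen on an aromatic carbon. Within the data shown here, no measured step covers a methyl on this core, and the single step available is unreadable, so no change beyond the scatter is expected in this assay. Compound 4 is therefore estimated at 500000 nM (range 300000 nM to 1000000 nM), most likely again reported as a limit; the expected step is a step that the limit leaves unreadable from compound 3 to compound 4.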

Compound 4, half-maximal cytotoxic concentration: > 432000 nM
Compound 4: only a limit was reported (the forecaster's own chance of this, stated with the estimate: 90%); the middle value does not contradict the limit.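

With compound 3 and compound 4 both reported only as limits in this assay, no step can be read between them. The compounds shown leave open where the actual cytotoxic concentration of any of them lies.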